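The source may report more compounds than this note shows. Statements on the series, on what has been measured and on what is new or still open speak of the compounds shown alone.

Measured so far:
compound 1 `CCC1C(=O)N(C)c2cnc(-n3ccc4cc(C(=O)NCC(C)C)ccc43)nc2N1c1ccn(C)n1` — 5070 nM
compound 2 `CCNC(=O)c1ccc2c(ccn2-c2ncc3c(n2)N(C2CCCC2)[C@H](CC)C(=O)N3C)c1` — 596 nM

In a functional assay on Huh-7 cells (Homo sapiens) for antiproliferative activity, read by CCK-8 assay, with a stated time of 72 h (a higher number here means a weaker inhibitor of growth, a lower number a stronger inhibitor of growth), compound 1 gives 5070 nM and stands highest of the two numbers. Compound 2 gives 596 nM, a lower number by a gap beyond the scatter. Compound 3 `CCCNC(=O)c1ccc2c(ccn2-c2ncc3c(n2)N(c2ccn(C)n2)C(CC)C(=O)N3C)c1` is not yet measured; it differs from compound 1 by hydrogen in place of methyl on a saturated chain carbon bound to two saturated chain carbons. Among the compounds with values here, no measured pair isolates this change, so the expected move in this assay is small, most likely none beyond the scatter, with a slight drift in either direction possible. Compound 3 is expected at 4500 nM, in the range 2000 nM to 10000 nM. The expected step is a 1.1-fold lower number from compound 1 to compound 3 (0.05 log units; within the scatter).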

Compound 3, concentration for 50% growth inhibition: 7280 nM
The estimate for compound 3 lay 1.6-fold (0.21 log units) below the measured number, and the stated range covers the measured number.
By their numbers in this assay, from the lowest: compound 2; then compounds 1 and 3 (each within the scatter of the next).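

In this assay, within the data shown here, the first single-place comparison is isobutylamino to propylamino, with a 1.4-fold higher number from compound 1 to compound 3 (0.16 log units; within the scatter). Loss of this methyl on a saturated chain carbon bound to two saturated chain carbons therefore has no effect that can be told from the scatter, so the branch is not needed to hold the number at this level. Nothing available explains the result. On these data alone, whether a longer chain, an amine or a carboxylic acid at this place would shift the number remains open.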